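Swapping a Fluorobenzyl Group for a Dimethoxybenzyl Group

The compounds below may be only part of what the source reports. "The series", "measured", "known", "first", "only" and "open" are said of these compounds alone.

Within the data shown here, compound 1, `O=C(NCc1cn(Cc2ccc(F)cc2)nn1)c1cn(-c2ccccc2)nc1-c1ccccc1`, is one of two compounds measured in a functional assay on HeLa cells (Homo sapiens) for antiproliferative activity, read by sulforhodamine B assay, with a stated time of 48 h (a higher number here means a weaker inhibitor of growth, a lower number a stronger inhibitor of growth), and compound 1 gives 1600 nM, the higher of the two numbers. Among the measured compounds shown here, its only measured neighbour, compound 2, `O=C(NCc1cn(Cc2ccc(Cl)cc2)nn1)c1cn(-c2ccccc2)nc1-c1ccccc1`, gives 600 nM; the single known step is a 2.7-fold lower number from compound 1 to compound 2 (0.43 log units; beyond the scatter). Compound 3, `COc1cc(Cn2cc(CNC(=O)c3cn(-c4ccccc4)nc3-c3ccccc3)nn2)cc(OC)c1`, is not yet measured and differs from compound 1 in one place: 3,5-dimethoxyphenyl in place of 4-fluorophenyl on a saturated chain carbon bound to an aromatic nitrogen. The measured step bears on this only indirectly: it shows that exchanging the substituent on the 4-fluorobenzyl group can move the number beyond the scatter, but the group that enters here is not the chloro of compound 2, so no direction follows from it. The step expected is therefore small, a 1.3-fold lower number from compound 1 to compound 3 (0.12 log units; within the scatter), with wide uncertainty. The estimate for compound 3 is 1200 nM, expected to lie between 400 nM and 4000 nM.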

Compound 3, concentration for 50% growth inhibition: 12200 nM
Compound 3: the middle estimate sits 10-fold (1.01 log units) below what was measured; measured number outside the range, above it.
By their numbers in this assay, from the lowest: compound 2; then compound 1; then compound 3.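

In this assay, this place on the saturated chain carbon bound to an aromatic nitrogen proves far less forgiving than the exchange of one halogen for another suggested: 3,5-dimethoxyphenyl in place of 4-fluorophenyl gives a clear loss of growth inhibition (a 7.6-fold higher number from compound 1 to compound 3 (0.88 log units; beyond the scatter)), and 3,5-dimethoxyphenyl in place of 4-chlorophenyl gives a larger one (a 20-fold higher number from compound 2 to compound 3 (1.31 log units; beyond the scatter)). Of the three groups shown here, 3,5-dimethoxyphenyl therefore goes with the weakest inhibitor of growth, so a larger substituted ring at this place is not simply tolerated. No measurement at hand explains why this change weakens growth inhibition.

The compounds shown leave open whether the loss follows the methoxy groups themselves or their number. They also leave open how a plain phenyl, a phenyl carrying one methoxy group or a phenyl carrying an amine would stand at this place.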